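The source may hold more compounds than are shown below. What is called first, only, known or untested is meant among the compounds shown, and "the series" means these compounds.

Within the data shown here, in an assay for inhibition of serine/threonine-protein kinase PLK2 (Homo sapiens), read by FRET and Z'-LYTE, with a stated time of 1 h (a lower number here means a stronger inhibitor, a higher number a weaker inhibitor), compound 1 `CC[C@@H]1C(=O)N(C)c2cnc(-n3ccc4cc(C(=O)NC)ccc43)nc2N1C1CCCC1` gives 8.6 nM, the lowest of the two numbers so far. Compound 2 `CCC1C(=O)N(C)c2cnc(Nc3ccc(S(N)(=O)=O)cc3)nc2N1c1ccn(C)n1` gives 121 nM, a gap beyond the scatter, though the two structures differ in more than one place, so only the two values themselves stand. Compound 3 `CC[C@@H]1C(=O)N(C)c2cnc(-n3ccc4cc(C(=O)NCC(C)C)ccc43)nc2N1C1CCCC1` carries isopropyl in place of hydrogen on a saturated chain carbon bound to an amide-type nitrogen, read one bond further out as methylcarbamoyl to isobutylcarbamoyl. Among the measured compounds shown here, no pair of measured compounds isolates this change. The step of a 1.5-fold higher number from compound 1 to compound 3 (0.18 log units; within the scatter) is expected to be small, within the scatter or a modest loss. Compound 3 is estimated at 13 nM, with a range from 4 nM to 45 nM.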

Compound 3, half-maximal inhibitory concentration: 18.6 nM
Estimate against measurement, compound 3: 1.4-fold (0.16 log units) below; measured number inside the range.
By their numbers in this assay, from the lowest: compound 1; then compound 3; then compound 2.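

Methylcarbamoyl to isobutylcarbamoyl is the first single-place change readable in the series: in this assay it gives a 2.2-fold higher number from compound 1 to compound 3 (0.34 log units; beyond the scatter) and is a modest loss. This chain carbon therefore accepts isopropyl in place of hydrogen at only a modest cost, at least on the core of compound 1. Nothing available accounts for the size of this step.

Still open, from the compounds shown here alone, is whether a longer chain, a terminal amine or a carboxylic acid at this place would keep the number close to that of compound 1. Going by these compounds, whether the step carries over to other cores also remains unknown.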